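The compounds below may be only part of what the source reports. "The series", "measured", "known", "first", "only" and "open" are said of these compounds alone.

Series notes. Three compounds carry measurements in an assay on a protein complex for inhibition of CDK8/Cyclin C (Homo sapiens), with a stated time of 1 h; a lower number here means a stronger inhibitor, a higher number a weaker inhibitor. Compound 1, `CCOC(=O)/C=C/c1ccncc1-c1ccc2c(ccn2C)c1`, gives 144 nM. Compound 2, `COC(=O)/C=C/c1ccncc1-c1ccc2ccccc2c1`, gives 40.6 nM. Compound 3, `CNC(=O)/C=C/c1ccncc1-c1ccc2cccnc2c1`, gives 1760 nM. Compound 2 holds the lowest number of the three: compound 1 stands nearest, beyond the scatter, and compound 3 furthest, also beyond the scatter. Within the data shown here, no pair of measured compounds differs in a single place, so no step between them can be read.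

The unmeasured compound 4, `CCOC(=O)/C=C/c1ccncc1-c1ccc2ccccc2c1`, differs from compound 2 in one place: methyl in place of hydrogen on a saturated chain carbon bound to an oxygen next to a carbonyl group, methoxycarbonyl to ethoxycarbonyl. Among the measured compounds shown here, no measured pair isolates this change; compound 1 carries the ethoxycarbonyl group, but the rest of its structure differs from compound 2 as well, so that comparison mixes two changes. In this assay the expected step for compound 4 is small, most likely none beyond the scatter, with a slight lean toward a higher number. Compound 4 is estimated at 55 nM, within a range of 20 nM to 150 nM. The estimated step of a 1.4-fold higher number from compound 2 to compound 4 (0.13 log units; within the scatter) is expected to stay within the scatter.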

Compound 4, half-maximal inhibitory concentration: 53.3 nM
Compound 4: middle estimate off by 1.0-fold (0.01 log units), on the high side; low and high end bracket the measured number.
By their numbers in this assay, from the lowest: compounds 2 and 4 (each within the scatter of the next); then compound 1; then compound 3.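

With ethoxycarbonyl in place of methoxycarbonyl, this assay shows a 1.3-fold higher number from compound 2 to compound 4 (0.12 log units; within the scatter), so this one added methyl on the saturated chain carbon bound to an oxygen next to a carbonyl group leaves the number within the scatter. Among these compounds, this is the first reading of this position on its own: compound 1 also carries ethoxycarbonyl, but the rest of its structure differs from compound 2, and its number could not separate the two changes. No supporting measurement bears on the reason for this result.

On these data alone, whether the number stays within the scatter with a longer chain at this position, such as propyl or butyl, remains open. So does the outcome of replacing the whole group with a carboxylic acid on the core of compound 2.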